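The source may hold more compounds than are shown below. What is called first, only, known or untested is meant among the compounds shown, and "the series" means these compounds.

Compound 1 `O=C1/C(=C/c2cccc(Br)c2)Cc2ccccc21` gives 32400 nM
Compound 2 `Cc1ccc(/C=C2\Cc3ccccc3C2=O)cc1` gives 67100 nM

In a functional assay on CCRF-CEM cells (Homo sapiens) for inhibition (a higher number here means a weaker inhibitor, a lower number a stronger inhibitor), compound 1 has the lower of the two numbers, which makes it the stronger inhibitor of the pair, and the gap to compound 2 lies beyond the usual scatter. The next compound to be measured is compound 3 `COc1cccc(/C=C2\Cc3ccccc3C2=O)c1`, which has methoxy in place of bromo on an aromatic carbon and otherwise keeps the core of compound 1. For the measured compounds named here, no measured pair shows this exchange directly. Going by the values given here, the only guide is the small gap between compound 1 at 32400 nM and compound 2 at 67100 nM, so a small move towards a higher number is expected in this assay. The expected change is a 1.4-fold higher number from compound 1 to compound 3 (0.14 log units; within the scatter) and may not clear the scatter. For compound 3 the estimated value is 45000 nM, with an expected range from 20000 nM to 100000 nM.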

Compound 3, half-maximal inhibitory concentration: > 500000 nM
Compound 3 ended at the assay's limit (the forecaster's own chance of this, stated with the estimate: 10%); middle value at least 11-fold (1.04 log units) from the limit.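

In this assay, methoxy in place of bromo on an aromatic carbon, meta to a large group, brings an at least 15-fold higher number from compound 1 to compound 3 (1.18 log units; beyond the scatter), so the two groups at this one place are far from interchangeable. Compound 3 gives > 500000 nM, which is a limit of the assay and not a number. The step therefore gives only a lower bound on the change, and its full size cannot be read: the limit of > 500000 nM in this assay, at which 1 of the 3 values shown sits.

The compounds shown do not tell what separates bromo from methoxy at this place, since the exchange alters the atoms present and nothing else about the two groups is measured here. On these data alone, whether chloro, a hydroxyl or an amine on the same aromatic carbon would stay near compound 1 or fall towards compound 3 remains open.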